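Phenyl to benzyl on the double-bonded nitrogen

The compounds below may be only part of what the source reports. "The series", "measured", "known", "first", "only" and "open" are said of these compounds alone.

Compound 1 `[O-]/[N+](=C\c1cn(-c2ccccc2)nn1)c1ccccc1` is the unsubstituted parent of the set. In a functional assay on A549 cells (Homo sapiens) for inhibition, read by MTT assay, with a stated time of 24 h (a higher number here means a weaker inhibitor, a lower number a stronger inhibitor), compound 1 gives only a limit, > 100000 nM, which is the limit of > 100000 nM in this assay, at which 1 of the 3 values shown sits; where it truly stands is not known. Compound 2 `[O-]/[N+](=C\c1cn(-c2ccc(F)cc2)nn1)c1ccccc1` gives 12500 nM in this assay, and compound 3 `[O-]/[N+](=C\c1cn(-c2ccc(Cl)cc2)nn1)c1ccccc1` gives 10500 nM. The measured steps all concern an aromatic carbon away from the site now in question: an at least 8.0-fold lower number from compound 1 to compound 2 (0.90 log units; beyond the scatter), an at least 9.5-fold lower number from compound 1 to compound 3 (0.97 log units; beyond the scatter), and a 1.2-fold lower number from compound 2 to compound 3 (0.08 log units; within the scatter). Compound 4 `[O-]/[N+](=C\c1cn(-c2ccccc2)nn1)Cc1ccccc1` changes a different place, (benzyl in place of phenyl on a double-bonded nitrogen). Within the data shown here, none of the measured steps touches the double-bonded nitrogen, so there is no measured step that sets the size or direction of this change. With compound 1 at a limit, the working expectation is a step of no size beyond the scatter in this assay, most probably another limit. Compound 4 is therefore estimated at 100000 nM, with a range from 30000 nM to 300000 nM. That estimate means an expected a number no higher from compound 1 to compound 4 (the limit leaves the size open).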

Compound 4, half-maximal inhibitory concentration: > 100000 nM
Compound 4: only a limit was reported; the forecaster's own chance of this, stated with the estimate: 70%; the middle value sits exactly at the limit.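

Compound 1 and compound 4 both stand at a limit in this assay, so no step can be read for benzyl in place of phenyl on the double-bonded nitrogen: the limit of > 100000 nM in this assay, at which 2 of the 4 values shown sit. The compounds shown leave open where either compound truly stands and whether this change shifts the number at all.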